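A few compounds are considered here, and "the series" means these few. Any claim that something is new, unique, unknown or untested is made for them only; others in the source may bear on it.

Compound 1 `C=CCc1cccc(CC=C)c1OC(C)C1=NCCN1` gives 0.9 in an assay on CHO cells with Alpha-2C adrenergic receptor (Homo sapiens) as the target; a higher number here means a larger maximal response, a lower number a smaller maximal response. Compound 2 `C=C(C)c1ccccc1OC(C)C1=NCCN1` gives 0.71 in this assay. Compound 3 `CC(=O)c1ccccc1OC(C)C1=NCCN1` gives 0.65 in this assay.

Compound 2 stands second highest of the three; compound 3 lies nearest, the change from compound 2 to compound 3 being a number 0.060 lower from compound 2 to compound 3 (within the scatter), within the scatter, while compound 1 lies furthest, beyond the scatter.

Compound 4 `COc1ccccc1OC(C)C1=NCCN1` differs from compound 2 in one place: methoxy in place of 1-methylethenyl on an aromatic carbon. Going by the values given here, the one measured step that bears on it is the change from compound 2 to compound 3, a number 0.060 lower from compound 2 to compound 3 (within the scatter), where a substituent at the same place was swapped without a shift beyond the scatter. Compound 4 is therefore expected to show a step of a number 0.010 lower from compound 2 to compound 4 (within the scatter) in this assay, none beyond the scatter. Compound 4 is estimated at 0.7, between 0.5 and 0.9.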

Compound 4, intrinsic activity: the largest response reached, as a fraction of the reference agonist's: 0.6
Estimate against measurement, compound 4: 0.10 above; low and high end bracket the measured number.
By their numbers in this assay, from the lowest: compounds 4, 3 and 2 (each within the scatter of the next, the first and the last beyond it); then compound 1.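

In this assay, going by these compounds alone, methoxy in place of 1-methylethenyl on an aromatic carbon gives a number 0.11 lower from compound 2 to compound 4 (beyond the scatter) and is thus the first swap at this position to pass beyond the scatter, showing that the group held here can shift the maximal response. Methoxy in place of acetyl gives a number 0.050 lower from compound 3 to compound 4 (within the scatter) and so does not separate these two groups. No measurement at hand accounts for either step.

On these data alone, whether an amine, a hydroxyl or a chlorine at this position would raise or lower the maximal response stays open. So does how a longer chain such as ethoxy would compare with methoxy.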